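Deacetylation at the allylic oxygen of compound 1

The source may hold more compounds than are shown below. What is called first, only, known or untested is meant among the compounds shown, and "the series" means these compounds.

Compound 1 `COc1ccc(C(=O)O[C@H]2CC(C)=C[C@H](OC(C)=O)[C@@]3(C)[C@@H](OC(C)=O)C[C@@](O)(C(C)C)[C@H]23)cc1` gives 39600 nM in a functional assay on K562 cells (Homo sapiens) for cytotoxicity, read by MTT assay, with a stated time of 72 h (on this read-out lower numbers stand for stronger inhibition and higher numbers for weaker inhibition), the lower of two numbers; compound 2 `COc1ccc(C(=O)O[C@H]2CC(C)=CC[C@@]3(C)CC[C@@](O)(C(C)C)[C@H]23)cc1` gives 67800 nM there, a gap within the scatter. Compound 3 `COc1ccc(C(=O)O[C@H]2CC(C)=C[C@H](O)[C@@]3(C)[C@@H](OC(C)=O)C[C@@](O)(C(C)C)[C@H]23)cc1` differs from compound 1 by hydrogen in place of acetyl on an oxygen on a saturated carbon, leaving the other acetyl in place. Among the measured compounds shown here, no comparable step between measured compounds exists, so the expected step is set near no change: a 1.1-fold higher number from compound 1 to compound 3 (0.06 log units; within the scatter) is expected, with the estimate leaning slightly toward a higher number. Compound 3 is expected to give about 45000 nM, within 15000 nM to 130000 nM.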

Compound 3, half-maximal inhibitory concentration: 48200 nM
Compound 3: the middle estimate sits 1.1-fold (0.03 log units) below what was measured; the measured number falls inside the stated range.
By their numbers in this assay, from the lowest: compounds 1, 3 and 2 (each within the scatter of the next).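

In this assay, acetoxy to hydroxy on this oxygen on a saturated carbon gives the first step read at this position (a 1.2-fold higher number from compound 1 to compound 3 (0.09 log units; within the scatter)), and the other acetyl stays in place. The acetyl here can therefore give way to hydrogen with the two values remaining within the scatter. No measurement bears on why this is so.

Open, going by these compounds, is whether a longer acyl chain, a methyl ether or an amine on this oxygen would read the same. On these data alone, the effect of replacing the other acetyl alone also remains open.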